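Reaching out from the amine: a longer chain on compound 2

This account rests on a few compounds, and the source may have more. Where it says the series, first, only, none or still open, it means among the compounds named here.

Three compounds sharing a core have been examined in a functional assay on MCF7 cells (Homo sapiens) for cytotoxicity, read by MTT assay, with a stated time of 72 h; a lower number here means a stronger inhibitor, a higher number a weaker inhibitor. Compound 1, `NCCCNc1c(C(=O)NCc2ccc(F)cc2)ncc2cccnc12`, reports only a limit of the assay in this assay, > 10000 nM. Compound 3, `O=C(NCc1ccc(F)cc1)c1nc(Br)c2cccnc2c1N1CCNCC1`, gives 7000 nM in this assay. Compound 2, `C[C@H](CO)Nc1nc(C(=O)NCc2ccc(F)cc2)c(O)c2ncccc12`, stands apart: in this assay compound 2 has "not determined" (no result reported), so no number anchors it among the others. Of the values that are shown, one sits at the limit, (the limit of > 10000 nM in this assay, at which 1 of the 3 values shown sits), and the other is a single weak figure, so the known ground here is narrow and lies at the weak end.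

Compound 4, `O=CNCCCCCCNc1nc(C(=O)NCc2ccc(F)cc2)c(O)c2ncccc12`, differs from compound 2 in one place: 6-(formylamino)hexyl in place of 1-(hydroxymethyl)ethyl on a nitrogen on an aromatic ring. For the measured compounds named here, no measured pair in this set shows the effect of such a change, so the expected size of the step in this assay is not fixed by data. The shown values for compound 1 and compound 3 give no reason to expect a move beyond the scatter in either direction, and an outcome as weak as those seems the most likely.

Compound 4 is therefore estimated at 7000 nM in this assay, with a range from 2000 nM to 20000 nM.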

Compound 4, half-maximal inhibitory concentration: 19000 nM
Beside the measured number, compound 4's estimate is 2.7-fold (0.43 log units) below it; the range from low to high includes it.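

In this assay compound 4 gives 19000 nM but compound 2 has no number, so no step from compound 2 to compound 4 can be read, and nothing shown bears on this result. Open, as far as these compounds go, is what replacing 1-(hydroxymethyl)ethyl with 6-(formylamino)hexyl does to cytotoxicity, and whether any compound on this shared core reaches a strong value.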